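The compounds below may be only part of what the source reports. "The series", "measured", "known", "first", "only" and "open" are said of these compounds alone.

Compound 2 `COc1ccccc1-c1cn2ccnc2c(-c2ccc3ncn(C4CCCCC4)c3c2)n1` stands lowest of the two numbers in a functional assay on Hs-578T cells (Homo sapiens) for inhibition, read by sulforhodamine B assay, with a stated time of 48 h, tested at 10 uM (on this read-out lower numbers stand for less inhibition and higher numbers for more inhibition at the one concentration tested (going by the name of the read-out)), where compound 2 gives 15.8%. Going by the values given here, compound 1 `Brc1ccc(-c2cn3ccnc3c(-c3ccc4ncn(C5CCCCC5)c4c3)n2)cc1` gives 24.5% in this assay, and the only measured step, a number 8.7 percentage points lower from compound 1 to compound 2 (within the scatter), lies within the scatter. Compound 3 `Fc1ccccc1-c1cn2ccnc2c(-c2ccc3ncn(C4CCCCC4)c3c2)n1` differs from compound 2 by one change: fluoro in place of methoxy on an aromatic carbon. Among the compounds with values here, that single step is the only guide, and it was small, so no step beyond the scatter is expected in this assay: the expected change is a number 2.2 percentage points higher from compound 2 to compound 3 (within the scatter). Compound 3 is therefore estimated at 18%, with a range from 5% to 32%.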

Compound 3, a percentage reported as inhibition, at one concentration (the size of the read-out at that concentration, not a potency): 5.26%
The estimate for compound 3 lay 12.7 percentage points above the measured number; low and high end bracket the measured number.
By their numbers in this assay, from the lowest: compound 3; then compounds 2 and 1 (each within the scatter of the next).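

In this assay, going by these compounds alone, fluoro in place of methoxy on this aromatic carbon, ortho to a large group, gives the first step beyond the scatter, a number 10.5 percentage points lower from compound 2 to compound 3 (beyond the scatter), so the group held here can move the number, which the earlier pair could not show. The step of a number 19.2 percentage points lower from compound 1 to compound 3 (beyond the scatter) is also beyond the scatter and separates 2-fluorophenyl from 4-bromophenyl. Nothing at hand explains why the fluoro compound reads lower. From the compounds shown here alone, it remains open how an amine or a carboxylic acid would read in this place, and whether fluoro would read the same on another carbon of that ring.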